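The source may report more compounds than this note shows. Statements on the series, on what has been measured and on what is new or still open speak of the compounds shown alone.

Values in a functional assay on L1210 cells (Mus musculus) for inhibition; a lower number here means a stronger inhibitor, a higher number a weaker inhibitor:
Compound 1 `C#CCN(Cc1ccc2nc(C)nc(O)c2c1)c1ccccc1`: > 6500 nM, a limit
Compound 2 `C#CCN(Cc1ccc2nc(C)nc(O)c2c1)c1ccc(C#N)cc1`: > 5000 nM, a limit
Compound 3 `C#CCN(Cc1ccc2nc(C)nc(O)c2c1)c1ccc(S(N)(=O)=O)cc1`: 20000 nM

Within the data shown here, compound 3, at 20000 nM, holds the only true number. The readings of compound 1 and compound 2 are limits. The next compound is compound 4 `C#CCN(Cc1ccc2nc(C)nc(O)c2c1)c1ccc(S(=O)(=O)N2CCOCC2)cc1`. The change is morpholin-4-yl in place of amino on a sulfonyl sulfur, which reads as morpholin-4-yl in place of amino on a sulfonyl sulfur, or sulfamoyl to (morpholin-4-yl)sulfonyl.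

Among the measured compounds shown here, two measured steps bear on this group: a step that the limit leaves unreadable from compound 1 to compound 3 and a step that the limit leaves unreadable from compound 2 to compound 3. Neither has a readable size, so neither gives a guide to direction or magnitude. For the measured compounds named here, no measured compound carries anything other than amino on the sulfonyl sulfur. The working expectation in this assay therefore stays anchored on compound 3 at 20000 nM, with no shift beyond the scatter and a wide margin on both sides. The expected move is no change at the digits printed from compound 3 to compound 4 (within the scatter). Compound 4 is estimated at 20000 nM, with an expected range of 6000 nM to 60000 nM.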

Compound 4, half-maximal inhibitory concentration: 3100 nM
Beside the measured number, compound 4's estimate is 6.5-fold (0.81 log units) above it, outside the stated range (below it).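

In this assay, among these compounds, the one step with a full size is a 6.5-fold lower number from compound 3 to compound 4 (0.81 log units; beyond the scatter), so what sits on the sulfonyl sulfur does move the read-out, and morpholin-4-yl carries the lower number. The two other new steps are floors only: an at least 2.0-fold lower number from compound 1 to compound 4 (0.32 log units; beyond the scatter), and an at least 1.6-fold lower number from compound 2 to compound 4 (0.20 log units; that floor lies within the scatter). These floors rest on the limits held by compound 1 and compound 2, and the steps among compound 1, compound 2 and compound 3 cannot be read.

As far as these compounds go, whether the lower number needs the morpholin-4-yl ring, with its ring oxygen, or follows from any replacement of amino on the sulfonyl sulfur stays open. Piperidin-1-yl or dimethylamino on the same sulfonyl sulfur would bear on that question.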